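Trifluoromethyl on the core of compound 1

A few compounds are considered here, and "the series" means these few. Any claim that something is new, unique, unknown or untested is made for them only; others in the source may bear on it.

Measured in an ADME assay on RAW264.7 cells (Mus musculus) for cytotoxicity, read by MTT assay, with a stated time of 72 h, tested at 50 ug/mL; a lower number here means less inhibition, a higher number more inhibition at the concentration tested (going by the name of the read-out):
compound 1 `CC(=O)c1ccc(N2CCN(C(=O)c3nc4ccccc4s3)CC2)cc1` 62.3%
compound 2 `CN1CCN(C(=O)c2nc3ccccc3s2)CC1` 52.1%
compound 3 `O=C(c1nc2ccccc2s1)N1CCN(c2ccccc2)CC1` 67.2%

Compound 1 sits within the scatter of compound 3, the step being a number 4.9 percentage points higher from compound 1 to compound 3 (within the scatter), while the gap between compound 1 and compound 2 is beyond the scatter. The other measured step, a number 15.1 percentage points higher from compound 2 to compound 3 (beyond the scatter), is modest. Both steps alter the substituent on the amine nitrogen in the ring, so neither bears on the change to compound 4 `CC(=O)c1ccc(N2CCN(C(=O)c3nc4cc(C(F)(F)F)ccc4s3)CC2)cc1`, which is trifluoromethyl in place of hydrogen on an aromatic carbon on the fused core. Among the measured compounds shown here, with no step of this kind measured, no change beyond the scatter is expected, and the estimated step is a number 0.3 percentage points lower from compound 1 to compound 4 (within the scatter). Compound 4 is therefore expected to give about 62%, with a range from 46% to 78% in this assay.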

Compound 4, a percentage reported as inhibition, at one concentration (the size of the read-out at that concentration, not a potency): 30.6%
Compound 4: middle estimate off by 31.4 percentage points, on the high side, and the stated range ends above it.
By their numbers in this assay, from the lowest: compound 4; then compound 2; then compounds 1 and 3 (each within the scatter of the next).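

Trifluoromethyl in place of hydrogen on this aromatic carbon gives a number 31.7 percentage points lower from compound 1 to compound 4 (beyond the scatter) in this assay. This position on the shared core, identical in compound 1, compound 2 and compound 3, therefore matters to the read-out, which those compounds alone could not show. No measured property bears on the cause of this step.

On these data alone, it remains open whether the step is specific to trifluoromethyl or would also follow a chlorine, a methoxy group or an amine on the same carbon. Also open, as far as these compounds go, is whether it carries over to the methyl-substituted amine of compound 2.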